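The compounds below may be only part of what the source reports. "The series", "measured", "known", "first", "only" and "open" are said of these compounds alone.

Measured compounds:
- compound 1, `Cc1nc(S(C)(=O)=O)ccc1Oc1ncnc(OC2CCN(C(=O)OC(C)F)CC2)c1F`: 68%
- compound 2, `Cc1nc(S(C)(=O)=O)ccc1Oc1ncnc(OC2CCN(C(=O)O[C@H](C)C(F)(F)F)CC2)c1F`: 85%
- compound 3, `Cc1nc(S(C)(=O)=O)ccc1Oc1ncnc(OC2CCN(C(=O)SC3CC3)CC2)c1F`: 80%

In a functional assay on isolated protein for inhibition of Glucose-dependent insulinotropic receptor (Rattus norvegicus), read by HTRF and cAMP accumulation (a higher number here means a larger maximal response, a lower number a smaller maximal response), compound 2 gives the highest of the three numbers. Compound 3 sits close to it, the pair separated by a number 5 percentage points lower from compound 2 to compound 3 (within the scatter); compound 1 lies further away, the step from compound 1 being a number 17 percentage points higher from compound 1 to compound 2 (beyond the scatter), with a number 12 percentage points higher from compound 1 to compound 3 (beyond the scatter) also clearing the scatter. All three compounds share the same core and differ only in the group on the carbonyl carbon.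

Compound 4, `CCc1cnc(C(=O)N2CCC(Oc3ncnc(Oc4ccc(S(C)(=O)=O)nc4C)c3F)CC2)nc1`, is not yet measured in this assay. Relative to compound 2 the change is 5-ethylpyrimidin-2-yl in place of 1-(trifluoromethyl)ethoxy on a carbonyl carbon. Among the compounds with values here, no measured step exchanges an oxygen-linked group for a ring-bearing carbon-linked group on that carbonyl carbon, so none bears on it directly; the steps 1>2 and 1>3 only show that changes at this position shift the maximal response by modest amounts, in either direction from the lowest member. The expected step from compound 2 to compound 4 in this assay is therefore a small downward one, a number 7 percentage points lower from compound 2 to compound 4 (within the scatter), not securely beyond the scatter. Compound 4 is estimated at 78%, with a range from 60% to 95%.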

Compound 4, largest response reached (reported as efficacy), in percent of the reference or control that the assay uses: 80%
Compound 4: the middle estimate sits 2 percentage points below what was measured, within the range that was stated.
By their numbers in this assay, from the lowest: compound 1; then compounds 3, 4 and 2 (each within the scatter of the next).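

In this assay, the carbonyl carbon on the amide-type ring nitrogen accepts a carbon-linked aromatic ring: 5-ethylpyrimidin-2-yl in place of 1-(trifluoromethyl)ethoxy gives a number 5 percentage points lower from compound 2 to compound 4 (within the scatter), and the same ring in place of cyclopropylsulfanyl gives no change at the digits printed from compound 3 to compound 4 (within the scatter). A linking oxygen or sulfur on this carbonyl carbon is therefore not needed to keep the maximal response of compound 2 and compound 3, while a number 12 percentage points higher from compound 1 to compound 4 (beyond the scatter) leaves compound 1 alone at the low end of the series. No available data explain these results.

Open, from the compounds shown here alone, is what the ethyl group contributes, which pyrimidin-2-yl without it, or with a propyl chain in its place, would show. Also open, going by these compounds, is how a nitrogen-linked group such as dimethylamino on this carbonyl carbon would compare.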